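This account rests on a few compounds, and the source may have more. Where it says the series, first, only, none or still open, it means among the compounds named here.

Compound 2 `CCCCCCc1cn(C(c2ccccc2)c2cc3cc(Br)ccc3nc2OC)nn1` is one of three compounds of the series measured in an ADME assay on SK-OV-3 cells (Homo sapiens) for cytotoxicity, read by sulforhodamine B assay, with a stated time of 48 h, tested at 10 uM; a lower number here means less inhibition, a higher number more inhibition at the concentration tested (going by the name of the read-out). In this assay compound 2 gives 7.17%, compound 1 `COc1nc2ccc(Br)cc2cc1C(c1ccccc1)n1cc(-c2ccc(Br)cc2)nn1` gives 13.4% and compound 3 `COc1nc2ccc(Br)cc2cc1C(c1ccccc1)n1cc(-c2ccccc2)nn1` gives 13.7%. The steps of a number 6.2 percentage points lower from compound 1 to compound 2 (within the scatter) and a number 6.5 percentage points higher from compound 2 to compound 3 (within the scatter) both stay within the scatter, as does a number 0.3 percentage points higher from compound 1 to compound 3 (within the scatter), so the three numbers do not separate and compound 2 cannot be set apart from the other two.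

Compound 4 `COc1nc2ccc(Br)cc2cc1C(c1ccccc1)n1cc(CCCCCO)nn1` differs from compound 2 in one place: hydroxy in place of methyl on a saturated chain carbon, five bonds along the chain from an aromatic carbon. Among the compounds with values here, none of the measured steps changes a group of this kind. The two steps that start or end at compound 2 replace the whole hexyl chain by an aromatic group, and even that larger swap, a number 6.2 percentage points lower from compound 1 to compound 2 (within the scatter) and a number 6.5 percentage points higher from compound 2 to compound 3 (within the scatter), moved the read-out by less than the scatter. The third step exchanges bromo for hydrogen on an aromatic carbon and also stays within the scatter. Nothing in the series therefore points to a move beyond the scatter for compound 4 in this assay; the expected step of a number 1.8 percentage points higher from compound 2 to compound 4 (within the scatter) is set near zero. Compound 4 is accordingly estimated at 9%, with a range from 1% to 19%.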

Compound 4, a percentage reported as inhibition, at one concentration (the size of the read-out at that concentration, not a potency): 8.69%
The estimate for compound 4 lay 0.3 percentage points above the measured number; low and high end bracket the measured number.
By their numbers in this assay, from the lowest: compounds 2, 4, 1 and 3 (each within the scatter of the next).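

In this assay, within the data shown here, hydroxy in place of methyl on a saturated chain carbon, five bonds along the chain from an aromatic carbon, gives a number 1.5 percentage points higher from compound 2 to compound 4 (within the scatter) and is the first change made on the chain itself; at this position the read-out does not separate the hexyl chain from the 5-hydroxypentyl chain. The aromatic groups do not separate from the new chain either, with a number 5 percentage points lower from compound 3 to compound 4 (within the scatter) for 5-hydroxypentyl in place of phenyl and a number 4.7 percentage points lower from compound 1 to compound 4 (within the scatter) for 5-hydroxypentyl in place of 4-bromophenyl, so the hydroxy-bearing chain does not stand apart from any of the three earlier substituents at this concentration. No supporting data bear on why these numbers stay together.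

Whether any substituent at this position can move the read-out beyond the scatter remains open, since all steps among these four compounds stay within it. An amine or a carboxylic acid at the end of the chain, or a longer chain carrying the hydroxy, would test whether this end of the molecule matters in this read-out at all.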